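Ring-methyl step from compound 2 to compound 3

A few compounds are considered here, and "the series" means these few. Any claim that something is new, unique, unknown or untested is made for them only; others in the source may bear on it.

Measured so far:
compound 1 `CN(C)C(=S)SC(=S)N1CCCC1` — 3090000 nM
compound 2 `CN(C)C(=S)SC(=S)N1CCCCC1` — > 5000000 nM

In an ADME assay on HeLa cells (Homo sapiens) for cytotoxicity, read by MTT assay, with a stated time of 24 h (on this read-out higher numbers stand for weaker inhibition and lower numbers for stronger inhibition), compound 1 gives 3090000 nM as a number. Compound 2 gives no number in this assay; its read-out > 5000000 nM is a limit of the assay. Compound 2 thus stands at the limit of > 5000000 nM in this assay, at which 1 of the 2 values shown sits, and cannot be placed more closely than that on the numbers shown.

Compound 3 `CC1CCCN(C(=S)SC(=S)N(C)C)C1` differs from compound 2 by methyl in place of hydrogen on a saturated ring carbon. Among the measured compounds shown here, no step between two measured compounds involves such a change, so nothing gives its size. Starting from a limit, the expectation for compound 3 is that a number no higher from compound 2 to compound 3 (the limit leaves the size open) amounts to no movement beyond the scatter in this assay. The estimate for compound 3 in this assay is 5000000 nM, with a range from 2500000 nM to 10000000 nM, and a considerable chance that this assay again reports only a limit.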

Compound 3, half-maximal inhibitory concentration: 2900000 nM
Compound 3: the middle estimate sits 1.7-fold (0.24 log units) above what was measured; the measured number falls inside the stated range.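

Methyl in place of hydrogen on a saturated ring carbon, two ring bonds from the ring nitrogen, gives an at least 1.7-fold lower number from compound 2 to compound 3 (0.23 log units; that floor lies within the scatter) in this assay. Among the compounds shown here, compound 3 reads as a number, 2900000 nM, so this is the first compound with the six-membered ring that gives a measured value rather than a limit. Compound 2 stands only at a limit, so the full size of the step stays open and only its floor, which lies within the scatter, can be read: the limit of > 5000000 nM in this assay, at which 1 of the 3 values shown sits.

As far as these compounds go, it remains open whether methyl on another carbon of the six-membered ring would give a similar number. Also open, from the compounds shown here alone, is how a different group on this same carbon, such as an ethyl chain, a hydroxyl or a primary amine, would move the read-out in this assay.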